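From acid to cyclopropyl amide in a growth assay

A few compounds are considered here, and "the series" means these few. Any claim that something is new, unique, unknown or untested is made for them only; others in the source may bear on it.

Measured so far in a functional assay on MCF7 cells (Homo sapiens) for inhibition, read by sulforhodamine B assay, with a stated time of 72 h; a higher number here means a weaker inhibitor of growth, a lower number a stronger inhibitor of growth:
Compound 1 `CNC(=O)/C=C/c1ccncc1-c1ccc2cc[nH]c2c1` gives 9230 nM
Compound 2 `O=C(O)/C=C/c1ccncc1-c1ccc2ccccc2c1` gives > 10000 nM

For compound 2 this value is a limit of this assay and not a number. Compound 3 `O=C(/C=C/c1ccncc1-c1ccc2ccccc2c1)NC1CC1` has not been measured yet. It carries cyclopropylamino in place of hydroxy on a carbonyl carbon and so has cyclopropylcarbamoyl where compound 2 has carboxy. Compound 1, also an amide but with a different core, gives 9230 nM and offers the only hint. A modest gain in inhibition is therefore expected, though compound 3 may also stay at the limit. The expected change is an at least 1.6-fold lower number from compound 2 to compound 3 (0.22 log units; that floor lies within the scatter) and points towards stronger inhibition. For compound 3 the estimated value is 6000 nM, with an expected range from 1500 nM to 10000 nM.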

Compound 3, concentration for 50% growth inhibition: 6840 nM
For compound 3 the middle estimate is 1.1-fold (0.06 log units) below the measured one, and the stated range covers the measured number.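

Compound 2 stands at a limit of this assay, which is not a number. With cyclopropylamino in place of hydroxy on a carbonyl carbon, compound 3 gives a true reading, and the change is an at least 1.4-fold lower number from compound 2 to compound 3 (0.16 log units; that floor lies within the scatter). The real size of this change stays unknown: the limit of > 10000 nM in this assay, at which 1 of the 3 values shown sits.

Still open, as far as these compounds go, is whether the three-membered ring matters or the amide alone is enough. A plain amino group or a propylamino chain on the same carbonyl carbon would tell these two apart.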